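Replacing the methoxycarbonylphenyl head of compound 1 with nitrophenyl

The source may report more compounds than this note shows. Statements on the series, on what has been measured and on what is new or still open speak of the compounds shown alone.

Measured so far:
compound 1, `COC(=O)c1ccc(COc2ccc(OCCOCCNC3CCCC3)cc2)cc1`: 6990 nM
compound 2, `c1ccc(COc2ccc(COc3ccc(OCCOCCNC4CCCC4)cc3)cc2)cc1`: 10000 nM
compound 3, `c1cc2c(cc1OCCOCCNC1CCCC1)CCCC2`: 31900 nM

In a functional assay on SK-OV-3 cells (Homo sapiens) for inhibition, read by CCK-8 assay, with a stated time of 70 h (on this read-out higher numbers stand for weaker inhibition and lower numbers for stronger inhibition), compound 1 gives the lowest of the three numbers. Compound 2 comes nearest, a 1.4-fold higher number from compound 1 to compound 2 (0.16 log units; within the scatter), and that gap is within the scatter, so the two cannot be ranked. Compound 3 sits furthest away, and its higher number lies beyond the scatter.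

Compound 4, `O=[N+]([O-])c1ccccc1COc1ccc(OCCOCCNC2CCCC2)cc1`, has not been measured. It differs from compound 1 in one place: 2-nitrophenyl in place of 4-(methoxycarbonyl)phenyl on a saturated chain carbon bound to an oxygen on an aromatic ring.

Within the data shown here, only one measured step touches the same region of the molecule, the exchange from compound 1 to compound 2, where a benzyloxy group replaced the methoxycarbonyl on the aromatic carbon and the number moved by a 1.4-fold higher number from compound 1 to compound 2 (0.16 log units; within the scatter), within the scatter. That single step suggests this head group tolerates change without a large shift. For compound 4 the expected step is therefore a 1.1-fold higher number from compound 1 to compound 4 (0.06 log units; within the scatter), none beyond the scatter. Compound 4 is estimated at 8000 nM, with a range from 3000 nM to 20000 nM.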

Compound 4, half-maximal inhibitory concentration: 5370 nM
Compound 4: the middle estimate sits 1.5-fold (0.17 log units) above what was measured, and the stated range covers the measured number.
By their numbers in this assay, from the lowest: compounds 4, 1 and 2 (each within the scatter of the next); then compound 3.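

In this assay, the exchange gives a 1.3-fold lower number from compound 1 to compound 4 (0.11 log units; within the scatter), so these two head groups cannot be ranked on this read-out. The earlier step at this head changed only the group carried by the phenyl ring, whereas this one replaces the whole 4-(methoxycarbonyl)phenyl with 2-nitrophenyl, and the number still stays within the scatter, so this place accepts a larger exchange than compound 2 alone showed. No supporting data are available to explain this result.

The compounds shown leave open whether a phenyl head carrying an amine or a carboxylic acid instead of the nitro group would give a similar number. From the compounds shown here alone, it is also open whether a longer chain linking the head to the oxygen-bearing aromatic ring would keep the number within the scatter.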